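A few compounds are considered here, and "the series" means these few. Any claim that something is new, unique, unknown or untested is made for them only; others in the source may bear on it.

In a functional assay on HCT-116 cells (Homo sapiens) for cytotoxicity, read by MTT assay, with a stated time of 48 h, in the presence of a further agent that is not named here (a higher number here means that more compound is needed for the effect, a lower number that less compound is needed), compound 1 (`Cc1c(Cc2ccccc2)c(NNC(=O)Nc2cc(Cl)nc(Cl)c2)nc2c1cnn2C`) gives 13600 nM and stands apart from the others. Compound 2 (`COc1cc(NC(=O)NNc2cc(-c3ccc(F)cc3)c3cnn(C)c3n2)cc(OC)c1OC`), which carries 4-fluorophenyl, gives 45300 nM in this test. Compound 3 (`Cc1nn(C)c2nc(NNC(=O)Nc3cc(Cl)nc(Cl)c3)cc(-c3ccco3)c12`) gives 69200 nM (within the scatter of compound 2, and beyond the scatter from compound 1, which needs less compound). Compound 4 (`Cc1nn(C)c2nc(NNC(=O)Nc3cc(Cl)nc(Cl)c3)cc(-c3ccc(F)cc3)c12`) has 4-fluorophenyl in place of furan-2-yl on an aromatic carbon. For the measured compounds named here, no measured pair shows this change alone, so no step beyond the scatter is expected in this assay, with any shift leaning towards lower numbers. The expected step is a 1.6-fold lower number from compound 3 to compound 4 (0.22 log units; within the scatter) (an estimate). The estimate for compound 4 is 42000 nM (expected range 16000 nM to 100000 nM).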

Compound 4, half-maximal effective concentration: 25200 nM
Estimate against measurement, compound 4: 1.7-fold (0.22 log units) above, and the stated range covers the measured number.
By their numbers in this assay, from the lowest: compounds 1, 4, 2 and 3 (each within the scatter of the next, the first and the last beyond it).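

In this assay the aromatic carbon opposite the ring nitrogen responds to its substituent: 4-fluorophenyl in place of furan-2-yl gives a 2.7-fold lower number from compound 3 to compound 4 (0.44 log units; beyond the scatter) and is the first step among these compounds that isolates a single change. That step lies beyond the scatter, but it rests on one pair alone. No measurement shown here accounts for the shift.

On these data alone, whether an amine or a carboxylic acid on this carbon would move the number further remains open. So does whether the same exchange would give a similar step with other groups elsewhere on the shared core.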